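The source may hold more compounds than are shown below. What is called first, only, known or untested is meant among the compounds shown, and "the series" means these compounds.

Measured so far in an assay for inhibition of Nicotinamide phosphoribosyltransferase (Homo sapiens), read by mass spectrometry, with stated times of 15 min and 30 min; a lower number here means a stronger inhibitor, a higher number a weaker inhibitor:
compound 1 `Cc1ccccc1S(=O)(=O)c1ccc(CNC(=O)c2cc3cnccc3[nH]2)cc1` gives 12 nM
compound 2 `O=C(NCc1ccc(S(=O)(=O)c2ccccc2)cc1)c1ccc2ncncc2c1` gives 1900 nM
compound 3 `O=C(NCc1ccc(S(=O)(=O)c2ccccc2)cc1)c1cc2ccncc2s1` gives 7 nM

Compound 3 has the lowest number of the three. Compound 1 sits within the scatter of it, so no order between them can be read. Compound 2 stands far beyond the scatter from both, the only clear gap in the set.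

Compound 4 `O=C(NCc1ccc(S(=O)(=O)c2ccccc2)cc1)c1nc2ccncc2s1` differs from compound 3 by a group of 9 heavy atoms (6 carbon, 2 nitrogen, 1 sulfur; one five-membered aromatic ring with 2 hetero atoms, one six-membered aromatic ring with 1 hetero atom) in place of a group of 9 heavy atoms (7 carbon, 1 nitrogen, 1 sulfur; one five-membered aromatic ring with 1 hetero atom, one six-membered aromatic ring with 1 hetero atom), on a carbonyl carbon. Within the data shown here, no measured pair tells what such an exchange does. The shared core is kept and the change is confined to one ring of the amide-side group, so the step from compound 3 to compound 4 is expected to be modest, a 2.1-fold higher number from compound 3 to compound 4 (0.33 log units; beyond the scatter), with a slight loss the more likely direction. Compound 4 is estimated at 15 nM, range 4 nM to 60 nM.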

Compound 4, half-maximal inhibitory concentration: 210 nM
Estimate against measurement, compound 4: 14-fold (1.15 log units) below; the whole stated range lies below it.
By their numbers in this assay, from the lowest: compounds 3 and 1 (each within the scatter of the next); then compound 4; then compound 2.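

In this assay, the exchange on the carbonyl carbon gives a 30-fold higher number from compound 3 to compound 4 (1.48 log units; beyond the scatter), so this place does not accept every closely similar group. The two groups have the same ring sizes and heavy-atom count, yet one more nitrogen and one fewer carbon, with a second hetero atom in the five-membered aromatic ring, is enough for a large step. Nothing at hand accounts for the size of this step.

As far as these compounds go, this exchange is read from one pair only, so whether it does the same with another shared core remains open. Also open, from the compounds shown here alone, is what a methyl group or a chlorine on the five-membered ring of compound 4 would do.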